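A few compounds are considered here, and "the series" means these few. Any claim that something is new, unique, unknown or untested is made for them only; others in the source may bear on it.

Compound 1 `COc1ccc(C(=O)O[C@H]2CC(C)=C[C@H](O)[C@@]3(C)[C@@H](OC(C)=O)C[C@@](O)(C(C)C)[C@H]23)cc1`: 34400 nM
Compound 2 `COc1ccc(C(=O)O[C@H]2CC(C)=C[C@@H](OC(C)=O)[C@@]3(C)[C@@H](OC(C)=O)C[C@@](O)(C(C)C)[C@H]23)cc1`: 42900 nM
Compound 3 `COc1ccc(C(=O)O[C@H]2CC(C)=C[C@H](OC(C)=O)[C@]3(C)[C@@H]2[C@](O)(C(C)C)C[C@@H]3O)cc1`: 26800 nM

In a functional assay on RS4-11 cells (Homo sapiens) for cytotoxicity, read by MTT assay, with a stated time of 72 h (on this read-out lower numbers stand for stronger inhibition and higher numbers for weaker inhibition), compound 3 gives the lowest of the three numbers, yet its gaps to compound 1 and to compound 2 both lie within the usual scatter, so the three measured compounds cannot be separated on this read-out. Compound 4 `COc1ccc(C(=O)O[C@H]2CC(C)=C[C@H](OC(C)=O)[C@@]3(C)[C@@H](OC(C)=O)C[C@@](O)(C(C)C)[C@H]23)cc1` has not been measured. Compared with compound 3 it carries acetyl in place of hydrogen on an oxygen on a saturated carbon. The three measured numbers sit close together, and the change from compound 3 to compound 4 is a small one, so no step beyond the scatter is expected in either direction; the expected step is a 1.1-fold higher number from compound 3 to compound 4 (0.05 log units; within the scatter). Compound 4 is therefore estimated to give 30000 nM, with a likely range from 12000 nM to 75000 nM.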

Compound 4, half-maximal inhibitory concentration: 2800 nM
Compound 4: the middle estimate sits 11-fold (1.03 log units) above what was measured; the measured number lies below the stated range.
By their numbers in this assay, from the lowest: compound 4; then compounds 3, 1 and 2 (each within the scatter of the next).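

In this assay, the change from hydroxy to acetoxy brings a 9.6-fold lower number from compound 3 to compound 4 (0.98 log units; beyond the scatter), and the same change on a different oxygen brings a 12-fold lower number from compound 1 to compound 4 (1.09 log units; beyond the scatter), so the low number appears only with both acetoxy groups in place. The drawn configuration at one saturated ring carbon counts as well, with a 15-fold lower number from compound 2 to compound 4 (1.19 log units; beyond the scatter): the fact that compounds 2 and 4 differ only in the configuration as drawn

The compounds shown leave open whether this holds only for acetyl or also for a longer chain such as propanoyl, or for a benzoyl group. They also leave open what an amine on either of these saturated carbons would give.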